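Replacing a Naphthyl Group with a Pyridyl Ring

This account rests on a few compounds, and the source may have more. Where it says the series, first, only, none or still open, it means among the compounds named here.

Measured compounds:
compound 1 `Cc1ccc(C(=O)Nc2sc3c(c2C(N)=O)CCN(Cc2c(Cl)cccc2Cl)C3)cc1`: 12300 nM
compound 2 `NC(=O)c1c(NC(=O)c2ccccc2Cl)sc2c1CCN(C(=S)Nc1cccc3ccccc13)C2`: 20700 nM
compound 3 `NC(=O)c1c(NC(=O)c2ccccc2Cl)sc2c1CCN(C(=S)Nc1cc(C(F)(F)F)cc(C(F)(F)F)c1)C2`: 15000 nM

In a functional assay on MKN-74 cells (Homo sapiens) for antiproliferative activity, with a stated time of 24 h (on this read-out higher numbers stand for weaker inhibition and lower numbers for stronger inhibition), compound 2 carries the highest of the three numbers, yet its gaps to compound 3 and to compound 1 both fall within the usual scatter, so the three compounds cannot really be set apart. Compound 4 `NC(=O)c1c(NC(=O)c2ccccc2Cl)sc2c1CCN(C(=S)Nc1cccnc1)C2` has not been measured. It differs from compound 2 in one place: pyridin-3-yl in place of naphthalen-1-yl on an amide-type nitrogen. For the measured compounds named here, no measured pair of compounds shows this kind of change, so its effect is unknown here. Compound 4 is therefore expected to stay close to compound 2, with at most a small step toward a weaker number in a 1.2-fold higher number from compound 2 to compound 4 (0.08 log units; within the scatter). The estimated value for compound 4 is 25000 nM, in a range from 10000 nM to 60000 nM.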

Compound 4, half-maximal inhibitory concentration: 38600 nM
The estimate for compound 4 lay 1.5-fold (0.19 log units) below the measured number; low and high end bracket the measured number.
By their numbers in this assay, from the lowest: compounds 1, 3, 2 and 4 (each within the scatter of the next, the first and the last beyond it).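

In this assay, for the compounds shown here, swapping naphthalen-1-yl for pyridin-3-yl on the amide-type nitrogen gives a 1.9-fold higher number from compound 2 to compound 4 (0.27 log units; within the scatter) and is the first single-place change that can be read at this position. One of the two carbon rings can therefore leave, and a ring nitrogen can enter, without a step beyond the usual scatter. The same four compounds give no other reading of this position.

Going by these compounds, whether phenyl, pyridin-4-yl or a simple alkylamine chain in this place would move the number beyond the scatter remains open. No measurement shown here bears on the reason for this result.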